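Replacing the benzyl group of compound 3: an estimate

The source may hold more compounds than are shown below. What is called first, only, known or untested is meant among the compounds shown, and "the series" means these compounds.

Three compounds have so far been measured in a physicochemical assay for lipophilicity, read by HPLC, at pH 7.4; a lower number here means a more polar compound, a higher number a more lipophilic compound:

compound 1 `CCc1cc2oc(=O)n(CCC(=O)O)c2cc1Cl`: 1.94
compound 2 `O=C(O)CCn1c(=O)oc2cc(Cl)c(Cl)cc21`: 1.61
compound 3 `O=C(O)CCn1c(=O)oc2cc(OCc3ccccc3)c(Cl)cc21`: 2.71

Compound 3 stands highest of the three, with compound 1 nearest and compound 2 furthest. The steps of a number 0.77 log units higher from compound 1 to compound 3 (beyond the scatter) and a number 1.10 log units higher from compound 2 to compound 3 (beyond the scatter) show how much the benzyloxy group lifts the number above an ethyl or a chloro group. Compound 4 `C[C@@H](Oc1cc2oc(=O)n(CCC(=O)O)c2cc1Cl)c1ncccn1` differs from compound 3 in a group of 8 heavy atoms (6 carbon, 2 nitrogen; one six-membered aromatic ring with 2 hetero atoms) in place of a group of 7 heavy atoms (7 carbon; one six-membered aromatic ring of carbon only), on an oxygen on an aromatic ring. Going by the values given here, no measured step exchanges one aromatic ring for another, so the size is uncertain; the entering group carries two hydrogen-bond acceptors where the leaving benzyl has none. A downward step beyond the scatter is expected, a number 1.01 log units lower from compound 3 to compound 4 (beyond the scatter). Compound 4 is estimated at 1.7, between 1.2 and 2.2.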

Compound 4, distribution coefficient: 0.83
Compound 4: middle estimate off by 0.87 log units, on the high side; measured number below the stated range.
By their numbers in this assay, from the lowest: compound 4; then compound 2; then compound 1; then compound 3.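

In this assay the exchange on the oxygen gives a number 1.88 log units lower from compound 3 to compound 4 (beyond the scatter), so a group of 8 heavy atoms in place of one of 7 can still move the number far at this position. Group size alone therefore does not set the number here, whereas the earlier steps all concerned an aromatic carbon. Nothing measured says which feature of the entering group, its ring or its defined stereocentre, accounts for the step. Still open, from the compounds shown here alone, is where a 1-phenylethyl or a pyridylmethyl group on the same oxygen would fall.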